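A methyl for fluoro swap on the furan amide

This account rests on a few compounds, and the source may have more. Where it says the series, first, only, none or still open, it means among the compounds named here.

Measured so far in an ADME assay on microsomes from liver (Homo sapiens) for metabolic stability, read by LC-MS, with a stated time of 60 min, tested at 1 uM; on this read-out lower numbers stand for slow clearance and higher numbers for fast clearance
compound 1 `O=C(Nc1ccc(F)c(-c2nc3ncccc3o2)c1)c1cnco1` gives 14 mL.min-1.g-1
compound 2 `O=C(Nc1ccc(F)c(-c2nc3ncccc3o2)c1)c1ccoc1` gives 154 mL.min-1.g-1

Compound 2 holds the higher of these two numbers, standing at 154 mL.min-1.g-1 in this assay and well clear of the scatter. Going by the values given here, the only measured step is large: an 11-fold higher number from compound 1 to compound 2 (1.04 log units; beyond the scatter) with furan-3-yl in place of 1,3-oxazol-5-yl on a carbonyl carbon. Compound 3 `Cc1ccc(NC(=O)c2ccoc2)cc1-c1nc2ncccc2o1` keeps that furan-3-yl and differs elsewhere methyl in place of fluoro on an aromatic carbon. Among the compounds with values here, the measured step lies at a different place, so it gives no direct guide, and no measured pair shows this swap. The expectation therefore rests on compound 2 at 154 mL.min-1.g-1 and foresees no step beyond the scatter. The expected change is a 1.2-fold higher number from compound 2 to compound 3 (0.09 log units; within the scatter) in this assay for this pair. Compound 3 is estimated at 190 mL.min-1.g-1 (expected range 85 mL.min-1.g-1 to 400 mL.min-1.g-1).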

Compound 3, intrinsic clearance in microsomes in the Homo sapiens assay: 176 mL.min-1.g-1
Beside the measured number, compound 3's estimate is 1.1-fold (0.03 log units) above it; the measured number falls inside the stated range.
By their numbers in the Homo sapiens assay, from the lowest: compound 1; then compounds 2 and 3 (each within the scatter of the next).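

In the Homo sapiens assay compound 2 gives 154 mL.min-1.g-1 and compound 3 gives 176 mL.min-1.g-1; methyl in place of fluoro, on the aromatic carbon para to the ((furan-3-yl)carbonyl)amino group, gives a 1.1-fold higher number from compound 2 to compound 3 (0.06 log units; within the scatter), so this position, which the earlier step did not touch, takes the change with the furan-3-yl held constant and without a shift past the scatter. In a physicochemical assay for lipophilicity, read by HPLC, at pH 7.4 (a lower number here means a more polar compound, a higher number a more lipophilic compound), compound 2 gives 2.4 and compound 3 gives 2.7; the same change gives a number 0.30 log units higher from compound 2 to compound 3 (within the scatter), so neither read-out separates the two compounds. Nothing at hand offers a reason for this outcome.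

On these data alone, whether a larger group on this carbon, such as methoxy or a longer alkyl chain, would also leave the clearance number in place remains open. Also open, as far as these compounds go, is whether the swap would read the same in the Homo sapiens assay with the 1,3-oxazol-5-yl of compound 1 in place of furan-3-yl.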